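The compounds below may be only part of what the source reports. "The series", "measured", "known", "first", "only" and "open" are said of these compounds alone.

Values measured so far in a physicochemical assay for lipophilicity, measured as octanol-water partition (a higher number here means a more lipophilic compound, a lower number a more polar compound), are these:
- compound 1 `COC(=O)c1cn(C/C=C(/C)CC/C=C(\C)CCC=C(C)C)nn1` gives 5.25
- compound 2 `CC(C)=CCC/C(C)=C/CC/C(C)=C/Cn1cc(-c2ccccc2)nn1` gives 6.95
- compound 3 `COC(=O)c1cn(C/C=C(\C)CCC=C(C)C)nn1` gives 3.2

Of these three, compound 3 (3.2) stands lowest. Compound 1 lies nearest to it and compound 2 furthest, both gaps beyond the scatter of repeated measurements. Compound 4 (`COC(=O)c1cn(C/C=C(\C)CC/C=C(\C)CCC=C(C)C)nn1`) differs from compound 3 by a single change (3-methylbut-2-en-1-yl in place of hydrogen on a saturated chain carbon bound to a double-bonded chain carbon): 3-methylbut-2-en-1-yl in place of hydrogen on a saturated chain carbon bound to a double-bonded chain carbon. Within the data shown here, no measured pair differing in one place shows the size of such a step, so the expectation in this assay rests on the values alone. The closest guide is compound 1 (5.25), which stands well above compound 3 and has the same ester end. A clear upward step, beyond the scatter, is therefore expected, and the estimated change is a number 2.00 log units higher from compound 3 to compound 4 (beyond the scatter) in size. For compound 4 the expected value is 5.2, with an estimated range from 4.75 to 5.65.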

Compound 4, partition coefficient: 5.25
Estimate against measurement, compound 4: 0.05 log units below; measured number inside the range.
By their numbers in this assay, from the lowest: compound 3; then compounds 1 and 4 (each within the scatter of the next); then compound 2.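

In this assay, 3-methylbut-2-en-1-yl in place of hydrogen on a saturated chain carbon bound to a double-bonded chain carbon gives a number 2.05 log units higher from compound 3 to compound 4 (beyond the scatter) and so puts a first measured size on this change. At the other end of the molecule, methoxycarbonyl in place of phenyl on an aromatic carbon gives a number 1.70 log units lower from compound 2 to compound 4 (beyond the scatter) with the chain unchanged, which shows a large step at that place too. The drawn configuration of one double bond gives no change at the digits printed from compound 1 to compound 4 (within the scatter) as its result, and the comparison isolates that single feature: the fact that compounds 1 and 4 differ only in the configuration as drawn.

The compounds shown leave open how a carboxylic acid or an amide on that aromatic carbon would compare with methoxycarbonyl and phenyl. They also leave open whether a longer chain would add a step of similar size.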